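Arylpiperazine sulfonamide series: nitro to acetyl on the aryl

The compounds below may be only part of what the source reports. "The series", "measured", "known", "first", "only" and "open" are said of these compounds alone.

Compound 1 `COc1ccc(S(=O)(=O)NCCCN2CCN(c3cccc(OC)c3)CC2)cc1` gives 339 nM in an assay on CHO cells for displacement of a labelled ligand from 5-hydroxytryptamine receptor 7 (Homo sapiens); on this read-out higher numbers stand for weaker inhibition and lower numbers for stronger inhibition.
Compound 2 `COc1ccc(N2CCN(CCCNS(=O)(=O)c3ccc(OC)cc3)CC2)cc1` gives 9310 nM in this assay.
Compound 3 `COc1ccc(S(=O)(=O)NCCCN2CCN(c3ccc([N+](=O)[O-])cc3)CC2)cc1` gives only a limit in this assay, > 10000 nM.

Compound 3 thus sits at the limit end of the numbers shown (the limit of > 10000 nM in this assay, at which 1 of the 3 values shown sits). Compound 4 `COc1ccc(S(=O)(=O)NCCCN2CCN(c3ccc(C(C)=O)cc3)CC2)cc1` differs from compound 3 only by acetyl in place of nitro on an aromatic carbon. For the measured compounds named here, the one measured step at this position, an at least 1.0-fold higher number from compound 2 to compound 3 (0.03 log units; that floor lies within the scatter), has a floor within the scatter. The steps of a 27-fold higher number from compound 1 to compound 2 (1.44 log units; beyond the scatter) and an at least 29-fold higher number from compound 1 to compound 3 (1.46 log units; beyond the scatter) place both para-substituted aryls far from compound 1. The change to acetyl keeps the para pattern, so in this assay no step beyond the scatter is expected, with a limit again likely. For compound 4 the estimate is 9000 nM (2500 nM to 30000 nM). The expected step is an at least 1.1-fold lower number from compound 3 to compound 4 (0.04 log units; that floor lies within the scatter).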

Compound 4, half-maximal inhibitory concentration: > 10000 nM
Compound 4 gave a limit, no number; the forecaster's own chance of this, stated with the estimate: 50%; middle value at least 1.1-fold (0.04 log units) from the limit.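

In this assay compound 4 gives only a limit, > 10000 nM. With 4-acetylphenyl in place of the 3-methoxyphenyl of the core of compound 1, the result is an at least 29-fold higher number from compound 1 to compound 4 (1.46 log units; beyond the scatter), and 4-acetylphenyl joins 4-nitrophenyl at the far end, while an at least 1.0-fold higher number from compound 2 to compound 4 (0.03 log units; that floor lies within the scatter) leaves it unseparated from the 4-methoxyphenyl of compound 2. The step between compound 3 and compound 4 cannot be read, and the limit now recurs in the series: the limit of > 10000 nM in this assay, at which 2 of the 4 values shown sit.

Open: whether an amine or a carboxylic acid in place of acetyl gives a value inside the assay's range, and how compound 3 and compound 4 truly compare.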